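Pyridinyl in place of methylphenyl on the diamino core

The source may hold more compounds than are shown below. What is called first, only, known or untested is meant among the compounds shown, and "the series" means these compounds.

Measured compounds:
compound 1 `Cc1cccc(Nc2nc3nonc3nc2Nc2ccccc2F)c1`: 1500 nM
compound 2 `Fc1ccccc1Nc1nc2nonc2nc1Nc1cccc(C(F)(F)F)c1`: its result in this assay is < 1000 nM, a limit of the assay and not a number.

In an assay on mitochondria from L6 cells (Rattus norvegicus) for activation, with a stated time of 90 min (on this read-out higher numbers stand for an effect only at larger amounts of compound and lower numbers for an effect already at smaller amounts), compound 1 gives 1500 nM, the only full number shown. Among the measured compounds shown here, the one further value, that of compound 2, is a limit of the assay. For the measured compounds named here, the single measured step runs an at least 1.5-fold lower number from compound 1 to compound 2 (0.17 log units; that floor lies within the scatter), with trifluoromethyl in place of methyl on an aromatic carbon; its floor sits within the scatter, and the pair rests on (the limit of < 1000 nM in this assay, at which 1 of the 2 values shown sits).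

Compound 3 `Fc1ccccc1Nc1nc2nonc2nc1Nc1ccccn1` is not yet measured. It differs from compound 1 by pyridin-2-yl in place of 3-methylphenyl on a nitrogen on an aromatic ring. Going by the values given here, the measured step concerns a substituent on the aromatic ring, not the exchange of the whole ring for a pyridin-2-yl, so no measured step bears directly on this change. With nothing to point to, the expectation is no step beyond the scatter. The step from compound 1 is estimated as no change at the digits printed from compound 1 to compound 3 (within the scatter). Compound 3 is expected to give about 1500 nM, within 400 nM to 5000 nM.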

Compound 3, half-maximal effective concentration: 9000 nM
For compound 3 the middle estimate is 6.0-fold (0.78 log units) below the measured one; measured number outside the range, above it.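

In this assay, pyridin-2-yl in place of 3-methylphenyl on a nitrogen on an aromatic ring gives a 6.0-fold higher number from compound 1 to compound 3 (0.78 log units; beyond the scatter), the only step shown that lies beyond the scatter. The position therefore responds to exchange of the whole ring, which the earlier substituent step, with its floor inside the scatter, could not show; the (pyridin-2-yl)amino group cannot be treated as an equivalent of (3-methylphenyl)amino on the shared core, although the two groups differ by only one hetero atom in the ring and the methyl group. The data shown include no measured property that bears on this step, so it stands as an observation without an assigned cause.

This single exchange removes the methyl group and brings in the ring nitrogen together, so unsubstituted phenyl, pyridin-3-yl and pyridin-4-yl, or a methyl-bearing pyridine, would be needed to separate the two changes and to test the placement of the nitrogen. As far as these compounds go, compound 2 remains a limit of the assay and not a number, at < 1000 nM, so the extent of any gain with trifluoromethyl also stays open.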